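The compounds below may be only part of what the source reports. "The series", "measured", "known", "first", "only" and "open" are said of these compounds alone.

Series notes. The three measured compounds share one core. Compound 1 `COc1cc2ncnc(-n3nc(-c4ccccn4)nc3N)c2cc1OCc1ccccc1` gives 8600 nM in an assay on MCF7 cells for inhibition of Serine-protein kinase ATM (Homo sapiens), read by immunofluorescence, with a stated time of 1 h; on this read-out higher numbers stand for weaker inhibition and lower numbers for stronger inhibition. Compound 2 `COc1cc2ncnc(-n3nc(-c4ccccn4)nc3N)c2cc1OCCCNC(=O)CN1C[C@@H](C)O[C@@H](C)C1` gives 1700 nM in this assay. Compound 3 `COc1cc2ncnc(-n3nc(-c4ccccn4)nc3N)c2cc1OCCNC(=O)OC(C)(C)C` gives 800 nM in this assay, the lowest number of the three, with compound 2 somewhat above it and compound 1 well above it. Among the compounds with values here, the single one-place step measured so far, an 11-fold lower number from compound 1 to compound 3 (1.03 log units; beyond the scatter), is large.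

Compound 4 `COc1cc2ncnc(-n3nc(-c4ccccn4)nc3N)c2cc1OCCCNC(=O)OCC(C)(C)C` is not yet measured. It differs from compound 3 by ((neopentyloxycarbonyl)amino)methyl in place of (tert-butoxycarbonyl)amino on a saturated chain carbon, two bonds along the chain from an oxygen on an aromatic ring. Within the data shown here, no measured step isolates this change. The step from compound 1 to compound 3 replaces phenyl with the carbamate-bearing group and says nothing about lengthening the chain or changing the carbamate ester from tert-butyl to neopentyl. Compound 2 carries a longer chain but a different terminal group, and its value of 1700 nM shows only that a longer chain can sit close to the level of compound 3. With the carbamate kept and the chain and ester both extended, the step of a 1.1-fold higher number from compound 3 to compound 4 (0.05 log units; within the scatter) is expected to stay within the scatter, with the direction uncertain. Compound 4 is therefore estimated at 900 nM in this assay, within a range of 350 nM to 2500 nM.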

Compound 4, half-maximal inhibitory concentration: 1900 nM
Estimate against measurement, compound 4: 2.1-fold (0.32 log units) below; measured number inside the range.
By their numbers in this assay, from the lowest: compound 3; then compounds 2 and 4 (each within the scatter of the next); then compound 1.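

In this assay, ((neopentyloxycarbonyl)amino)methyl in place of (tert-butoxycarbonyl)amino on a saturated chain carbon, two bonds along the chain from an oxygen on an aromatic ring, gives a 2.4-fold higher number from compound 3 to compound 4 (0.38 log units; beyond the scatter) and so shows that this position does not treat all carbamate-bearing chains alike, although chain and ester change together in this step. On the longer chain the end group counts for little in these data: neopentyloxy in place of (2,6-dimethylmorpholin-4-yl)methyl on a carbonyl carbon gives a 1.1-fold higher number from compound 2 to compound 4 (0.05 log units; within the scatter) and leaves the carbamate and the amide level. The replacement of phenyl still holds with the longer carbamate chain, at a 4.5-fold lower number from compound 1 to compound 4 (0.66 log units; beyond the scatter) for 2-((neopentyloxycarbonyl)amino)ethyl in place of phenyl, so the advantage over compound 1 does not depend on the exact chain of compound 3.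

The compounds shown leave open whether the step from the shorter chain belongs to the added chain carbon or to the neopentyl ester, a question that 3-((tert-butoxycarbonyl)amino)propyl would separate, and whether a free primary amine or a carboxylic acid at the chain end would hold the level of compound 3. Nothing given here bears on the cause of these differences.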